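The source may hold more compounds than are shown below. What is called first, only, known or untested is meant among the compounds shown, and "the series" means these compounds.

Compound 1 `CN(Cc1cccc(C(=O)O)c1)c1ccc(OCc2c(-c3c(Cl)cccc3Cl)noc2C2CC2)nc1C(F)(F)F`: 2 nM
Compound 2 `CN(Cc1ccc(C(=O)O)cc1)c1ccc(OCc2c(-c3c(Cl)cccc3Cl)noc2C2CC2)nc1C(F)(F)F`: 6 nM

Both were tested in a functional assay on HEK293 cells for agonist activity at Bile acid receptor (Homo sapiens), read by a luciferase reporter; on this read-out higher numbers stand for an effect only at larger amounts of compound and lower numbers for an effect already at smaller amounts. Of the two, compound 2 stands at the higher number, with compound 1 a step below it: a 3.0-fold higher number from compound 1 to compound 2 (0.48 log units; beyond the scatter). Compound 3 `CC(Nc1ccc(C(=O)O)cc1)c1ccc(OCc2c(-c3c(Cl)cccc3Cl)noc2C2CC2)nc1C(F)(F)F` holds the same atoms as compound 2, joined differently: 1-((4-carboxyphenyl)amino)ethyl in place of (4-carboxybenzyl)(methyl)amino on an aromatic carbon. Within the data shown here, no measured step covers such a rewiring of the linker; the single known step only shifts the carboxylic acid around its ring. With no direct guide, a modest move toward higher numbers is expected, with wide uncertainty. Compound 3 is therefore estimated at 15 nM, likely between 3 nM and 80 nM. This estimate amounts to an expected 2.5-fold higher number from compound 2 to compound 3 (0.40 log units; beyond the scatter).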

Compound 3, half-maximal effective concentration: 202 nM
Compound 3: the middle estimate sits 13-fold (1.13 log units) below what was measured; the whole stated range lies below it.
By their numbers in this assay, from the lowest: compound 1; then compound 2; then compound 3.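

Rewiring the linker on the aromatic carbon, with no atom gained or lost, moves the number in this assay much further than shifting the carboxylic acid around its ring does: a 34-fold higher number from compound 2 to compound 3 (1.53 log units; beyond the scatter), against a 3.0-fold higher number from compound 1 to compound 2 (0.48 log units; beyond the scatter). Measured against the 3-carboxybenzyl compound, the gap widens to a 100-fold higher number from compound 1 to compound 3 (2.00 log units; beyond the scatter). No measurement at hand explains a step of this size.

Still open, as far as these compounds go, is how a 1-((3-carboxyphenyl)amino)ethyl group would compare, and whether the moved nitrogen or the moved methyl accounts for the change.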